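Swapping One Piperidine Substituent on an Inactive Pair

A few compounds are considered here, and "the series" means these few. Any claim that something is new, unique, unknown or untested is made for them only; others in the source may bear on it.

Two compounds share a core built around a small ring carrying a carbonyl. Compound 1 `Cc1cccc(-c2noc(C3CN(C(=O)C4CCC(C(F)(F)F)CC4)C3)n2)c1` was tested in an assay on HEK293 cells for negative allosteric modulation of metabotropic glutamate receptor 5 (Homo sapiens), read by FLIPR; a lower number here means a stronger inhibitor, a higher number a weaker inhibitor. For compound 1 the assay reports only a limit, > 10000 nM. Compound 2 `O=C(N1CCC(F)CC1)N1CC(c2nc(-c3cccc(Cl)c3)no2)C1` was tested in the same way. For compound 2 the assay again reports only a limit, > 10000 nM. Both results sit at the limit of > 10000 nM in this assay, at which 2 of the 2 values shown sit, so neither compound shows measurable inhibition, and compound 2 stands at the weak edge of what this assay can record. Compound 3 `COC1CCCN(C(=O)N2CC(c3nc(-c4cccc(Cl)c4)no3)C2)C1` has not yet been measured. It differs from compound 2 in one place: 3-methoxypiperidin-1-yl in place of 4-fluoropiperidin-1-yl on a carbonyl carbon. Among the compounds with values here, no measured step between related compounds is available to size this change, so the expected step is a step that the limit leaves unreadable from compound 2 to compound 3, no more than the usual scatter. Compound 3 is therefore estimated at about 15000 nM in this assay, with a likely range from 5000 nM to 50000 nM, most probably reported again as a limit rather than a number.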

Compound 3, half-maximal inhibitory concentration: 1830 nM
Beside the measured number, compound 3's estimate is 8.2-fold (0.91 log units) above it; measured number below the stated range.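

In this assay the change on the carbonyl carbon gives an at least 5.4-fold lower number from compound 2 to compound 3 (0.73 log units; beyond the scatter) and so yields the only true reading among the compounds shown. This position is therefore not a dead end: 3-methoxypiperidin-1-yl, which counts one hydrogen-bond acceptor where 4-fluoropiperidin-1-yl counts none, is enough to bring inhibition into the measurable range. The true size of the step stays unknown, since compound 2 carries a limit rather than a number: the limit of > 10000 nM in this assay, at which 2 of the 3 values shown sit.

The compounds shown cannot separate the gain from adding the methoxy group, from its place on the ring and from losing the fluorine. They also leave open how 4-methoxypiperidin-1-yl, 3-hydroxypiperidin-1-yl or a longer ether chain would behave on this carbonyl carbon.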